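The compounds below may be only part of what the source reports. "The series", "measured", "known", "first", "only" and "open" are said of these compounds alone.

Compound 1 `Cc1ccccc1NC(=S)NC(=O)Nc1ccc2c(c1)C(=O)C(=O)N2Cc1ccccc1`: 2.98
Compound 2 `Cc1cccc(NC(=S)NC(=O)Nc2ccc3c(c2)C(=O)C(=O)N3Cc2ccccc2)c1`: 2.92

In a physicochemical assay for lipophilicity, in phosphate buffer, measured as octanol-water partition (a lower number here means a more polar compound, a higher number a more lipophilic compound), compound 1 gives 2.98 and stands highest of the two numbers, though the step of a number 0.06 log units lower from compound 1 to compound 2 (within the scatter) lies within the scatter. Compound 3 `Cc1ccccc1NC(=S)NC(=O)Nc1ccc2c(c1)C(=O)C(=O)N2Cc1ccccc1Cl` differs from compound 1 by chloro in place of hydrogen on an aromatic carbon. For the measured compounds named here, no measured step bears directly on this change; the only one known, 3-methylphenyl in place of 2-methylphenyl, did not move this assay beyond the scatter. For compound 3 a higher number is nevertheless expected, the estimated step being a number 0.62 log units higher from compound 1 to compound 3 (beyond the scatter). Compound 3 is therefore estimated at 3.6, between 3.3 and 3.9.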

Compound 3, partition coefficient: 3.7
Beside the measured number, compound 3's estimate is 0.10 log units below it; the range from low to high includes it.
By their numbers in this assay, from the lowest: compounds 2 and 1 (each within the scatter of the next); then compound 3.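

In this assay, replacing hydrogen with chloro to turn benzyl into 2-chlorobenzyl gives a number 0.72 log units higher from compound 1 to compound 3 (beyond the scatter), whereas the earlier step concerned only the methylphenyl group. This shows that a single chlorine on the benzyl ring, ortho to a large group, can move the number beyond the scatter. Nothing available accounts for this rise. On these data alone, whether a fluoro, a methoxy or an amine in the same place would move the number likewise remains open. So does whether chloro elsewhere on the benzyl ring would give a similar step.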